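A few compounds are considered here, and "the series" means these few. Any claim that something is new, unique, unknown or untested is made for them only; others in the source may bear on it.

Compound 3 `Cc1ccc(C(=O)O)cc1OCCCCOc1ccc(C(=O)CC(C)(C)C)c(O)c1C` gives 512 nM in an assay for positive allosteric modulation of metabotropic glutamate receptor 2 (Rattus norvegicus) (on this read-out lower numbers stand for an effect already at smaller amounts and higher numbers for an effect only at larger amounts of compound), the highest number among the three measured compounds. Compound 2 `Cc1c(OCCCCOc2ccc(Cl)c(C(=O)O)c2)ccc(C(=O)CC(C)(C)C)c1O` gives 87 nM and compound 1 `Cc1ncc(OCCCCOc2ccc(C(=O)CC(C)(C)C)c(O)c2C)cc1C(=O)O` gives 28 nM. The step from each of these two to compound 3 lies beyond the scatter. Compound 4 `Cc1c(OCCCCOc2ccc(C(=O)O)c(F)c2)ccc(C(=O)CC(C)(C)C)c1O` differs from compound 3 in 4-carboxy-3-fluorophenyl in place of 5-carboxy-2-methylphenyl on an oxygen on a saturated carbon. Every measured step sits at the same oxygen on a saturated carbon: a 3.1-fold higher number from compound 1 to compound 2 (0.49 log units; beyond the scatter), an 18-fold higher number from compound 1 to compound 3 (1.26 log units; beyond the scatter) and a 5.9-fold higher number from compound 2 to compound 3 (0.77 log units; beyond the scatter). Each exchange of this aryl group moved the number beyond the scatter, so a change is expected here too, most likely downward, since compound 3 already stands highest. Compound 4 is therefore estimated at 300 nM, between 70 nM and 1300 nM, which would mean a 1.7-fold lower number from compound 3 to compound 4 (0.23 log units; within the scatter).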

Compound 4, half-maximal effective concentration: 80 nM
The estimate for compound 4 lay 3.8-fold (0.57 log units) above the measured number; the measured number falls inside the stated range.
By their numbers in this assay, from the lowest: compound 1; then compounds 4 and 2 (each within the scatter of the next); then compound 3.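

In this assay, the exchange at this oxygen gives a 6.4-fold lower number from compound 3 to compound 4 (0.81 log units; beyond the scatter), which shows that a carboxy-bearing phenyl group without a ring nitrogen need not stand as high as compound 3. Two differently substituted phenyl groups also come out level, with a 1.1-fold lower number from compound 2 to compound 4 (0.04 log units; within the scatter), while the 5-carboxy-6-methylpyridin-3-yl group remains ahead of this new group, with a 2.9-fold higher number from compound 1 to compound 4 (0.46 log units; beyond the scatter). Nothing shown here explains these differences. Still open, on these data alone, is whether a tetrazole or an amide could take the place of the carboxylic acid on these rings, and how a shorter or longer chain would fare.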